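The source may report more compounds than this note shows. Statements on the series, on what has been measured and on what is new or still open speak of the compounds shown alone.

Three compounds carry a shared core joined through a benzylic or related linker to a biphenyl bearing a tetrazole, and all have been tested in a functional assay on the whole organism (artery) with Rattus norvegicus as the target, with a stated time of 60 min, at a dose of 3 mg/kg by the intraduodenal route; a higher number here means more inhibition at the dose given (going by the name of the read-out), a lower number less inhibition. Compound 1 `Cc1nc(C)c2c(n1)N(Cc1ccc(-c3ccccc3-c3nn[nH]n3)cc1)C(=O)C(C)C2` gives -63% in this assay, compound 2 `Cc1nc(C)c2c(n1)N(Cc1ccc(-c3ccccc3-c3nn[nH]n3)cn1)C(=O)CC2` gives -34%, and compound 3 `Cc1nc2c(c(C(F)(F)F)n1)CCC(=O)N2Cc1ccc(-c2ccccc2-c2nn[nH]n2)cc1` gives -68%. Compound 3 stands at the lowest of the three numbers; its gap to compound 1 lies within the scatter of repeated measurements, so no order between those two can be read, while its gap to compound 2 lies beyond the scatter.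

Compound 4 `Cc1nc(C(C)C)c2c(n1)N(Cc1ccc(-c3ccccc3-c3nn[nH]n3)cc1)C(=O)CC2` has not yet been measured. It differs from compound 3 in one place: isopropyl in place of trifluoromethyl on an aromatic carbon. Among the compounds with values here, no measured pair in this set isolates such a change, so there is no direct guide to its size. The expectation is that the step from compound 3 to compound 4 stays small, a number 8 percentage points higher from compound 3 to compound 4 (within the scatter), with no direction beyond the scatter. On that basis compound 4 is estimated at -60% in this assay, within a range from -85% to -30%.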

Compound 4, a percentage reported as inhibition, in the whole organism at one dose (the size of the read-out at that dose, not a potency): -44%
For compound 4 the middle estimate is 16 percentage points below the measured one; measured number inside the range.
By their numbers in this assay, from the lowest: compounds 3 and 1 (each within the scatter of the next); then compounds 4 and 2 (each within the scatter of the next).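

Within the data shown here, at the position opposite the ring nitrogen, the replacement of trifluoromethyl by isopropyl is the first change in this set confined to one place, and in this assay it gives a number 24 percentage points higher from compound 3 to compound 4 (beyond the scatter) and so marks this position as one where the group matters for the read-out at the dose given. The earlier compounds shown here could not show this, since none of them formed a pair differing in one place. Nothing at hand explains the size or the direction of this step.

As far as these compounds go, it remains open where an amine, a methoxy group or a cyclopropyl group on this aromatic carbon would fall relative to compound 3 and compound 4 in this assay at the same dose. Also open, from the compounds shown here alone, is whether the same exchange of trifluoromethyl for isopropyl would give a step of similar size with the linker of compound 2.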